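Tert-butoxycarbonyl in place of cyclopropylcarbonyl on compound 3

A few compounds are considered here, and "the series" means these few. Any claim that something is new, unique, unknown or untested is made for them only; others in the source may bear on it.

Of the compounds shown here, three sharing the core have been measured in a functional assay on WI-38 VA13 cells (Homo sapiens) for cytotoxicity; a lower number here means that less compound is needed, a higher number that more compound is needed for the effect. Compound 1 `O=C(Nc1ccc2nc(NC(=O)C3CCCCC3)sc2c1)c1ccccc1F` gives 0.14 ug/mL, compound 2 `O=C(Nc1ccc2nc(NC(=O)C3CCCCC3)sc2c1)c1c(F)cccc1C(F)(F)F` gives 0.032 ug/mL, and compound 3 `O=C(Nc1ccc2nc(NC(=O)C3CC3)sc2c1)c1c(Cl)cccc1Cl` gives 0.013 ug/mL. Compound 3 stands lowest of the three, beyond the scatter from both compound 2 and compound 1. Among the compounds with values here, the only single-change step measured, a 4.4-fold lower number from compound 1 to compound 2 (0.64 log units; beyond the scatter), sits at an aromatic carbon and not at the carbonyl carbon concerned here. Compound 4 `CC(C)(C)OC(=O)Nc1nc2ccc(NC(=O)c3c(Cl)cccc3Cl)cc2s1` differs from compound 3 by tert-butoxy in place of cyclopropyl on a carbonyl carbon. Within the data shown here, no measured step touches this position, so the change is expected to produce no shift beyond the scatter, a 1.5-fold higher number from compound 3 to compound 4 (0.19 log units; within the scatter). Compound 4 is therefore estimated at 0.02 ug/mL in this assay, within a range of 0.007 ug/mL to 0.06 ug/mL.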

Compound 4, half-maximal effective concentration: 0.027 ug/mL
Compound 4: the middle estimate sits 1.4-fold (0.13 log units) below what was measured; low and high end bracket the measured number.
By their numbers in this assay, from the lowest: compound 3; then compounds 4 and 2 (each within the scatter of the next); then compound 1.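

On the carbonyl carbon bonded to the amide-type nitrogen, tert-butoxy in place of cyclopropyl gives a 2.1-fold higher number from compound 3 to compound 4 (0.32 log units; beyond the scatter) in this assay, the first step read at this position. The step is modest, so this position accepts the loss of the cyclopropyl ring and the entry of a hydrogen-bond acceptor without a large change in the number. No measurement at hand accounts for the step.

Going by these compounds, it remains open how an amine or a longer chain on this carbonyl carbon would read. Also open, on these data alone, is whether the same exchange gives a similar step with the aromatic substituents of compound 2.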